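A few compounds are considered here, and "the series" means these few. Any claim that something is new, unique, unknown or untested is made for them only; others in the source may bear on it.

In a functional assay on MCF7 cells (Homo sapiens) for cytotoxicity, read by MTT assay (on this read-out higher numbers stand for weaker inhibition and lower numbers for stronger inhibition), compound 1 `O=C(/C=C/c1cc(O)c(O)c([N+](=O)[O-])c1)OCCc1ccccc1` gives 12300 nM. Compound 2 `COc1cc(/C=C/C(=O)OCCc2ccccc2)cc([N+](=O)[O-])c1O` gives > 300000 nM, which is a limit of the assay and not a number. Going by the values given here, the only measured step, an at least 24-fold higher number from compound 1 to compound 2 (1.38 log units; beyond the scatter), is large and puts methyl in place of hydrogen on an oxygen on the aromatic ring. Compound 3 `COc1cc(/C=C/C(=O)OCCc2ccccc2)cc(Br)c1O` keeps that methoxy group and has bromo in place of nitro on an aromatic carbon. Among the compounds with values here, no measured step covers this swap, so compound 3 is expected to remain weak, with at most a modest move towards stronger inhibition. The expected change is an at least 2.0-fold lower number from compound 2 to compound 3 (0.30 log units; that floor lies within the scatter). For compound 3 the estimated value is 150000 nM, with an expected range of 40000 nM to 400000 nM.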

Compound 3, half-maximal inhibitory concentration: > 300000 nM
Compound 3: only a limit was reported (the forecaster's own chance of this, stated with the estimate: 55%); middle value at least 2.0-fold (0.30 log units) away from the limit.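

Compound 2 and compound 3 both stop at a limit of the assay rather than a number, so no step can be read between them: the limit of > 300000 nM in this assay, at which 2 of the 3 values shown sit.

From the compounds shown here alone, whether bromo in place of nitro changes the result in this assay at all stays open.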